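A few compounds are considered here, and "the series" means these few. Any claim that something is new, unique, unknown or untested is made for them only; others in the source may bear on it.

Two compounds of the series have numbers in an assay on COS-7 cells for inhibition of sodium/nucleoside cotransporter 2 (Homo sapiens), read by scintillation counting, in the presence of a further agent that is not named here; on this read-out higher numbers stand for weaker inhibition and lower numbers for stronger inhibition. Compound 1 `Nc1ncnc2c1nc(NCc1ccc(Cl)cc1)n2[C@@H]1O[C@H](CO)[C@@H](O)[C@H]1O` gives 11000 nM. Compound 2 `Nc1ncnc2c1nc(NCc1cccc3ccccc13)n2[C@@H]1O[C@H](CO)[C@@H](O)[C@H]1O` gives 5700 nM. Going by the values given here, the single one-point step measured so far is a 1.9-fold lower number from compound 1 to compound 2 (0.29 log units; within the scatter), so compound 2 has the lowest of the two numbers, yet the gap to compound 1 lies within the scatter and no order between them can be claimed.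

Compound 3 `Cc1ccccc1CNc1nc2c(N)ncnc2n1[C@@H]1O[C@H](CO)[C@@H](O)[C@H]1O` differs from compound 2 in one place: 2-methylphenyl in place of naphthalen-1-yl on a saturated chain carbon bound to a nitrogen on an aromatic ring. Only the measured step between compound 1 and compound 2 bears on this change, since it likewise swaps the group on a saturated chain carbon bound to a nitrogen on an aromatic ring, and that step stayed within the scatter. No step beyond the scatter is therefore expected in this assay. The expected step is a 1.4-fold higher number from compound 2 to compound 3 (0.15 log units; within the scatter). Compound 3 is estimated to give 8000 nM in this assay, within 3000 nM to 20000 nM.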

Compound 3, half-maximal inhibitory concentration: 65000 nM
Beside the measured number, compound 3's estimate is 8.1-fold (0.91 log units) below it; the whole stated range lies below it.
By their numbers in this assay, from the lowest: compounds 2 and 1 (each within the scatter of the next); then compound 3.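

In this assay the group on a saturated chain carbon bound to a nitrogen on an aromatic ring now shows a clear effect on the number: 2-methylphenyl in place of naphthalen-1-yl gives an 11-fold higher number from compound 2 to compound 3 (1.06 log units; beyond the scatter) and 2-methylphenyl in place of 4-chlorophenyl gives a 5.9-fold higher number from compound 1 to compound 3 (0.77 log units; beyond the scatter) while the earlier swap stayed within the scatter. Ring count does not sort the three groups, as 4-chlorophenyl, also a single ring, stays within the scatter of naphthalen-1-yl and 2-methylphenyl does not. No available evidence gives a cause for these steps.

The compounds shown do not tell whether the methyl group itself carries the rise, which a plain phenyl group would help to settle. Going by these compounds, how this position responds to a longer chain between the nitrogen and the ring, or to an amine or a carboxylic acid on the ring, also remains open.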